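Adding a fluoro group and its expected effect on inhibition in this assay

The source may report more compounds than this note shows. Statements on the series, on what has been measured and on what is new or still open speak of the compounds shown alone.

Measured compounds:
compound 1, `O=C(CC1c2ccccc2N=C(SCCCCCN2CCCC2)N1c1ccc(-c2ccc(F)cc2)cc1)NCc1ccc(F)cc1`, 35.1%
compound 2, `CN(C)CCCCCSC1=Nc2ccccc2C(CC(=O)NCc2ccc(F)cc2)N1c1ccc(-c2ccccc2)cc1`, 69.3%

In an assay on cells for inhibition of Voltage-dependent T-type calcium channel subunit alpha-1I (Homo sapiens), read by patch clamp, tested at 10 uM (a lower number here means less inhibition, a higher number more inhibition at the concentration tested (going by the name of the read-out)), compound 2 gives the higher of the two values, and compound 1 sits well below it, beyond the usual scatter. Compound 2 and compound 1 differ in more than one place, so the two values alone do not show which part matters.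

Compound 3, `CN(C)CCCCCSC1=Nc2ccccc2C(CC(=O)NCc2ccc(F)cc2)N1c1ccc(-c2ccc(F)cc2)cc1`, differs from compound 2 by one change: fluoro in place of hydrogen on an aromatic carbon. Among the measured compounds shown here, with no single-change pair measured, the step is expected to be small, likely within the scatter: a number 9.3 percentage points lower from compound 2 to compound 3 (within the scatter). Compound 3 is expected to give about 60%, between 35% and 80%.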

Compound 3, a percentage reported as inhibition, at one concentration (the size of the read-out at that concentration, not a potency): 92%
Compound 3: middle estimate off by 32 percentage points, on the low side, and the stated range ends below it.
By their numbers in this assay, from the lowest: compound 1; then compound 2; then compound 3.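

In this assay, phenyl to 4-fluorophenyl is not a silent swap: it gives a number 22.7 percentage points higher from compound 2 to compound 3 (beyond the scatter) and so raises inhibition at this position. The end of the chain counts as well, as dimethylamino in place of pyrrolidin-1-yl gives a number 56.9 percentage points higher from compound 1 to compound 3 (beyond the scatter) with the fluoro group kept in both compounds. Nothing measured here explains either step.

Going by these compounds, whether chloro or methoxy at the same aromatic carbon would do as well remains open. So does whether a piperidine at the chain end would keep this level of inhibition.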